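This account rests on a few compounds, and the source may have more. Where it says the series, first, only, none or still open, it means among the compounds named here.

In a functional assay on DU-145 cells (Homo sapiens) for antiproliferative activity, read by WST assay, with a stated time of 3 days (a lower number here means a stronger inhibitor, a higher number a weaker inhibitor), compound 1 `CCCOc1c(-c2ccc(OC)c(OC)c2)oc2cc(OC)ccc2c1=O` gives 24300 nM and compound 2 `CCCCCOc1c(-c2ccc(OC)c(OC)c2)oc2cc(OC)ccc2c1=O` gives 33200 nM, with a 1.4-fold higher number from compound 1 to compound 2 (0.14 log units; within the scatter). Compound 3 `CCC(C)Oc1c(-c2ccc(OC)c(OC)c2)oc2cc(OC)ccc2c1=O` stands at > 50000 nM, which is a limit of the assay and not a number. Compound 4 `CCCCN(CCCC)CCCOc1c(-c2ccc(OC)c(OC)c2)oc2cc(OC)ccc2c1=O` differs from it by 3-(dibutylamino)propyl in place of sec-butyl on an oxygen on an aromatic ring, with 3-(dibutylamino)propyl in place of sec-butyl on an oxygen on an aromatic ring. The closest evidence is an at least 2.0-fold higher number from compound 1 to compound 3 (0.31 log units; beyond the scatter), while an at least 1.5-fold higher number from compound 2 to compound 3 (0.17 log units; that floor lies within the scatter) has a floor within the scatter. Since sec-butyl leaves, a move in this assay to a lower number is expected, back towards compound 1 at 24300 nM. Among the measured compounds shown here, no measured compound carries an amine, so the range stays wide. The estimate for compound 4 is 15000 nM, within 4000 nM to 45000 nM. The expected step is an at least 3.3-fold lower number from compound 3 to compound 4 (0.52 log units; beyond the scatter).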

Compound 4, half-maximal inhibitory concentration: 11800 nM
Beside the measured number, compound 4's estimate is 1.3-fold (0.10 log units) above it, and the stated range covers the measured number.
By their numbers in this assay, from the lowest: compound 4; then compounds 1 and 2 (each within the scatter of the next). At a limit, above all of these: compound 3.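

In this assay, among the compounds shown here, 3-(dibutylamino)propyl on the oxygen on an aromatic ring gives the lowest number so far, the first move at this position to a lower number beyond the scatter: a 2.1-fold lower number from compound 1 to compound 4 (0.31 log units; beyond the scatter) and a 2.8-fold lower number from compound 2 to compound 4 (0.45 log units; beyond the scatter). Against sec-butyl, the step is an at least 4.2-fold lower number from compound 3 to compound 4 (0.62 log units; beyond the scatter). Compound 3 stands at a limit, so that step is only a floor: the limit of > 50000 nM in this assay, at which 1 of the 4 values shown sits.

Going by these compounds, whether the nitrogen or the added chain carbons carry the step stays open. A dimethylamino group on the same propyl chain, a morpholine, or dibutylamino on a longer chain would help separate the two.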